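The compounds below may be only part of what the source reports. "The series", "measured", "known", "first", "only" and "open" are said of these compounds alone.

Working notes on a small set built around a shared core. In a functional assay on MIA PaCa-2 cells (Homo sapiens) for antiproliferative activity, read by MTT assay, with a stated time of 72 h (a lower number here means a stronger inhibitor, a higher number a weaker inhibitor), compound 1 `COc1cc(/C=C\c2cc3cc(F)ccc3s2)cc(OC)c1OC` gives 200 nM as its result and compound 3 `COc1cc(/C=C\c2sc3ccccc3c2C)cc(OC)c1OC` gives 120 nM as its result, so these two numbers lie within the scatter of each other. Compound 2 `COc1ccc2sc(/C=C\c3cc(OC)c(OC)c(OC)c3)cc2c1` carries the entry "not determined" (no result reported) and adds nothing to the comparison. For the measured compounds named here, compound 3 therefore stands level with compound 1 on the only two numbers available.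

Compound 4 `COc1cc(/C=C\c2cc3ccccc3s2)cc(OC)c1OC` is still unmeasured. Its difference from compound 3 hydrogen in place of methyl on an aromatic carbon amounts to hydrogen in place of methyl on an aromatic carbon, next to the ring atom that bears a large group. Going by the values given here, no measured pair isolates this change. The closest guide is compound 1, which also has hydrogen at that place and gives 200 nM in the same range as compound 3. The expected change is a 1.3-fold higher number from compound 3 to compound 4 (0.10 log units; within the scatter) and it is estimated to stay within the scatter, with a slight drift toward a higher number. In this assay the estimated value for compound 4 is 150 nM with an expected range of 55 nM to 420 nM as the working figure.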

Compound 4, half-maximal inhibitory concentration: 7.8 nM
For compound 4 the middle estimate is 19-fold (1.28 log units) above the measured one; the whole stated range lies above it.
By their numbers in this assay, from the lowest: compound 4; then compounds 3 and 1 (each within the scatter of the next).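

In this assay the methyl group at this carbon, next to the ring atom that bears a large group, carries a heavy cost, with a 15-fold lower number from compound 3 to compound 4 (1.19 log units; beyond the scatter), a loss that compound 1 alone could not reveal. The fluoro group on compound 1 also goes with a much higher number, at a 26-fold lower number from compound 1 to compound 4 (1.41 log units; beyond the scatter), so among the measured compounds each single replacement by hydrogen gives a large gain and neither goes against this. Nothing shown accounts for the size of either step.

Going by these compounds, whether any group at the methyl position can match hydrogen stays open, since only methyl and hydrogen appear there; an ethyl group, a chloro group or an amine would test this. At the fluoro position, compound 2 has no reported result, so hydrogen has only fluoro to be compared against, and a chloro or hydroxyl group there remains an open question.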